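Trading the two-ring amide group in compound 2 for difluorophenyl

The source may hold more compounds than are shown below. What is called first, only, known or untested is meant among the compounds shown, and "the series" means these compounds.

Compound 1 `COc1cccc(OC)c1C(=O)Nc1c[nH]nc1C(=O)NC1CC1`: > 50000 nM
Compound 2 `CO[C@H]1CC[C@H](NC(=O)c2n[nH]cc2NC(=O)c2cc3ccccn3n2)CC1`: 1000 nM
Compound 3 `COc1cccc(OC)c1C(=O)Nc1c[nH]nc1C(=O)NCCCN(C)C`: > 50000 nM

In an ADME assay on MRC5 cells (Homo sapiens) for inhibition, with a stated time of 72 h (on this read-out higher numbers stand for an effect only at larger amounts of compound and lower numbers for an effect already at smaller amounts), compound 2 gives 1000 nM. Among the compounds with values here, this is the only actual number among the three results; the other two are limits of the assay. Compound 1 gives > 50000 nM, a limit rather than a number. Compound 3 likewise gives > 50000 nM, again a limit. Within the data shown here, the single measured step, a step that the two limits leave unreadable from compound 1 to compound 3, runs between two limits and is therefore unreadable; it changes the amide nitrogen, not the carbonyl side, so it does not bear on the present change.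

Compound 4 `CO[C@H]1CC[C@H](NC(=O)c2n[nH]cc2NC(=O)c2cc(F)cc(F)c2)CC1` differs from compound 2 by a group of 8 heavy atoms (6 carbon, 2 fluorine; one six-membered aromatic ring of carbon only) in place of a group of 9 heavy atoms (7 carbon, 2 nitrogen; one five-membered aromatic ring with 2 hetero atoms, one six-membered aromatic ring with 1 hetero atom), on a carbonyl carbon. Among the measured compounds shown here, no measured step covers this kind of swap. For the measured compounds named here, what the values do show is that compound 2, the only compound carrying the two-ring amide group, is also the only one with a number, while compound 1 and compound 3 sit at the limit of > 50000 nM in this assay, at which 2 of the 3 values shown sit. On that thin basis, the step is expected to weaken activity: for compound 4 the estimate is 5000 nM, with a range from 1500 nM to 30000 nM. This expectation corresponds to a step of a 5.0-fold higher number from compound 2 to compound 4 (0.70 log units; beyond the scatter), with a real chance that only a limit is returned.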

Compound 4, half-maximal effective concentration: 600 nM
Compound 4: middle estimate off by 8.3-fold (0.92 log units), on the high side, outside the stated range (below it).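

In this assay, a 1.7-fold lower number from compound 2 to compound 4 (0.22 log units; within the scatter), so replacing the two-ring group with 3,5-difluorophenyl on this carbonyl carbon makes no change that can be told apart from repeat-measurement scatter. The earlier compounds shown here left open the idea that a measurable number belonged to the two-ring group alone, and compound 4 goes against that idea: it has a single six-membered carbon ring, with no ring nitrogen and no hydrogen-bond acceptor in the entering group, yet still returns a number. Compound 1 and compound 3 still give only limits of the assay, and both differ from compound 4 in more than one place, so they cannot be read as steps for this change: the limit of > 50000 nM in this assay, at which 2 of the 4 values shown sit.

As far as these compounds go, what remains open is whether the limits of compound 1 and compound 3 come from the group on this carbonyl carbon or from the other amide; placing the group that compound 1 carries here into compound 4, in place of 3,5-difluorophenyl, would separate the two. From the compounds shown here alone, it is also open how far this position tolerates change, for example an unsubstituted phenyl or a phenyl ring carrying an amine or a carboxylic acid.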